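Phenyl for phenethyl at two places along a saturated chain

The source may hold more compounds than are shown below. What is called first, only, known or untested is meant among the compounds shown, and "the series" means these compounds.

Compound 1 `O=C(CCCCc1ccccc1)CC(=O)N[C@H]1CCOC1=O`: 80000 nM
Compound 2 `O=C(CCCCCCc1ccccc1)CC(=O)N[C@H]1CCOC1=O`: 27000 nM
Compound 3 `O=C(CCCCCCCCCCc1ccccc1)N[C@H]1CCOC1=O`: 66000 nM

Of the compounds shown here, three have been measured in a functional assay on NCI-H630 cells (Homo sapiens) for cytotoxicity, read by sulforhodamine B assay, with a stated time of 5 days; on this read-out lower numbers stand for stronger inhibition and higher numbers for weaker inhibition. Among them, compound 2 gives 27000 nM, while the step of a 3.0-fold higher number from compound 2 to compound 1 (0.47 log units; beyond the scatter) corresponds to the change (phenyl in place of phenethyl on a saturated chain carbon, four bonds along the chain from a carbonyl carbon). The difference between the cores of compound 2 and compound 3 is not broken down here.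

Compound 4, `O=C(CCCCCCCCc1ccccc1)N[C@H]1CCOC1=O`, is not yet measured. It differs from compound 3 by the same kind of change, (phenyl in place of phenethyl on a saturated chain carbon, eight bonds along the chain from a carbonyl carbon), though the place is eight bonds along the chain from a carbonyl carbon rather than four. The step made by this change is estimated at a 1.8-fold higher number from compound 3 to compound 4 (0.26 log units; within the scatter), resting on the earlier step of a 3.0-fold higher number from compound 2 to compound 1 (0.47 log units; beyond the scatter); as the two places are not the same, less weight is put on matching its size. Compound 4 is therefore expected to give about 120000 nM in this assay, with a plausible range from 45000 nM to 320000 nM.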

Compound 4, half-maximal inhibitory concentration: > 100000 nM
Compound 4: no number, only a limit; the forecaster's own chance of this, stated with the estimate: 25%; the middle value lies beyond the limit too.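

In this assay compound 4 gives > 100000 nM, which is a limit of the assay and not a number. Phenyl in place of phenethyl, eight bonds along the chain from a carbonyl carbon, gives an at least 1.5-fold higher number from compound 3 to compound 4 (0.18 log units; that floor lies within the scatter), which points the same way as the earlier step but is only a floor. The change may therefore carry from one core to the other in direction, but neither a matching nor a differing size is shown: the same change on two cores in this assay, a 3.0-fold higher number (0.47 log units; beyond the scatter) from compound 2 to compound 1 and an at least 1.5-fold higher number (0.18 log units; that floor lies within the scatter) from compound 3 to compound 4; the limit leaves it open whether they differ

The compounds shown leave open how either core would respond to an amine or a carboxylic acid in place of the phenyl. They also leave open whether a longer chain would follow the same course.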